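The source may hold more compounds than are shown below. What is called first, only, known or untested is meant among the compounds shown, and "the series" means these compounds.

In an ADME assay on CHO cells (Cricetulus griseus) for cytotoxicity, read by MTT assay, with a stated time of 24 h (a lower number here means that less compound is tolerated, a higher number that more compound is tolerated), the measured compounds are:

Compound 1 `CC1Cn2c(nc([N+](=O)[O-])c2Br)O1`: 9190 nM
Compound 2 `CC1Cn2c(nc([N+](=O)[O-])c2-c2ccc(CO)cc2)O1`: > 500000 nM

Compound 2 gives > 500000 nM, which is a limit of the assay and not a number. Compound 3 `CC1Cn2c(nc([N+](=O)[O-])c2-c2ccc(Cl)cc2)O1` carries chloro in place of hydroxymethyl on an aromatic carbon of compound 2: chloro in place of hydroxymethyl on an aromatic carbon. Within the data shown here, no measured pair shows this change, so the expectation is loose: a drop to a lower number in this assay, beyond the usual scatter. The expected size is an at least 5.5-fold lower number from compound 2 to compound 3 (0.74 log units; beyond the scatter). Compound 3 is estimated at 90000 nM, with an expected range of 15000 nM to 500000 nM.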

Compound 3, half-maximal cytotoxic concentration: > 250000 nM
Compound 3: only a limit was reported; the forecaster's own chance of this, stated with the estimate: 35%; at least 2.7-fold (0.44 log units) between middle value and limit.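

Compound 2 and compound 3 each give only a limit in this assay, not a number, and no step can be read between them. From the compounds shown here alone, whether chloro in place of hydroxymethyl changes how much compound the cells tolerate stays open.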